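A Second Chlorine on a Purine-like Core

A few compounds are considered here, and "the series" means these few. Any claim that something is new, unique, unknown or untested is made for them only; others in the source may bear on it.

Going by the values given here, compound 1 `ClCc1cccc(Cn2cnc3ncnc(Cl)c32)c1` gives the lowest of the two numbers known so far: in a functional assay on NCI-H322M cells (Homo sapiens) for cytotoxicity, read by sulforhodamine B assay, with a stated time of 48 h (a higher number here means a weaker inhibitor of growth, a lower number a stronger inhibitor of growth), compound 1 gives 1990 nM. Compound 2 `ClCc1cccc(Cn2cnc3c(Cl)nc(Cl)nc32)c1` gives 2290 nM in this assay, a value within the scatter of compound 1, so no order can be read between them. Compound 3 `ClCc1cccc(Cn2cnc3nc(Cl)nc(Cl)c32)c1` differs from compound 1 by one change: chloro in place of hydrogen on an aromatic carbon, on the carbon between two ring nitrogen atoms. Among the compounds with values here, no measured pair shows this exact step, so the step is expected to be small, in no clear direction, and within the scatter. Compound 3 is estimated at 2200 nM, with a range from 1000 nM to 5000 nM, which means an expected step of a 1.1-fold higher number from compound 1 to compound 3 (0.04 log units; within the scatter).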

Compound 3, concentration for 50% growth inhibition: 14100 nM
The estimate for compound 3 lay 6.4-fold (0.81 log units) below the measured number, outside the stated range (above it).
By their numbers in this assay, from the lowest: compounds 1 and 2 (each within the scatter of the next); then compound 3.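

In this assay chloro in place of hydrogen on the aromatic carbon between two ring nitrogen atoms gives a 7.1-fold higher number from compound 1 to compound 3 (0.85 log units; beyond the scatter) and so weakens growth inhibition at this position. Compound 2 also carries a second chloro, elsewhere on the shared core, yet its value lies within the scatter of compound 1, so the place of the added chlorine matters in these compounds. Nothing available explains this loss.

As far as these compounds go, whether fluoro, methyl or an amine on this carbon would also raise the number remains open.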